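The source may hold more compounds than are shown below. What is called first, only, known or untested is meant among the compounds shown, and "the series" means these compounds.

Three compounds share one core, a long unsaturated acyl chain on an amide nitrogen, and differ only in the aromatic group on that nitrogen. In an assay on microsomes from intestine for inhibition of acyl-CoA:cholesterol acyltransferase (Oryctolagus cuniculus) (a higher number here means a weaker inhibitor, a lower number a stronger inhibitor), compound 2 `CCCCCCCC/C=C/CCCCCCCC(=O)Nc1ccccc1C(C)C` gives 600 nM, the lowest of the numbers obtained. Compound 1 `CCCCCCCC/C=C/CCCCCCCC(=O)Nc1ccccc1OC` gives 8000 nM in this assay. For compound 3 `CCCCCCCC/C=C/CCCCCCCC(=O)Nc1ccccc1C(=O)c1ccccc1` this assay reports only a limit, > 10000 nM; this is the limit of > 10000 nM in this assay, at which 1 of the 3 values shown sits. The step of a 13-fold lower number from compound 1 to compound 2 (1.12 log units; beyond the scatter) was large, and the step of an at least 16-fold higher number from compound 2 to compound 3 (1.22 log units; beyond the scatter) was large as well, so compound 2 stands apart from both of the others. Compound 4 `CCCCCCCC/C=C/CCCCCCCC(=O)Nc1ccc(F)cc1F` differs from compound 2 in that (2,4-difluorophenyl in place of 2-isopropylphenyl on an amide-type nitrogen). Within the data shown here, no measured step exchanges the aromatic group in this manner, and both changes away from the isopropyl compound that were measured gave much higher numbers. One therefore expects a step upward beyond the scatter, an 8.3-fold higher number from compound 2 to compound 4 (0.92 log units; beyond the scatter), and estimates for compound 4 a value of 5000 nM in this assay, within the range 1500 nM to 20000 nM.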

Compound 4, half-maximal inhibitory concentration: 32000 nM
The estimate for compound 4 lay 6.4-fold (0.81 log units) below the measured number, outside the stated range (above it).
By their numbers in this assay, from the lowest: compound 2; then compound 1; then compound 4.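

Compound 4 shows that a low number in this assay does not come with every aromatic group on this amide-type nitrogen: 2,4-difluorophenyl in place of 2-isopropylphenyl gives a 53-fold higher number from compound 2 to compound 4 (1.73 log units; beyond the scatter) in a single exchange. The two groups have much in common, each being one six-membered aromatic ring of carbon only with no hydrogen-bond donors or acceptors, so these shared features do not suffice for the number of compound 2. The same group also fares worse than 2-methoxyphenyl, with a 4.0-fold higher number from compound 1 to compound 4 (0.60 log units; beyond the scatter), and nothing given here accounts for either step.

On these data alone, the exchange removes the isopropyl group and adds both fluorines at once, so their separate contributions remain open. As far as these compounds go, how an ethyl or tert-butyl group would compare with isopropyl, or chlorine with fluorine, also remains open.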